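A few compounds are considered here, and "the series" means these few. Any claim that something is new, unique, unknown or untested is made for them only; others in the source may bear on it.

Compound 1 `CC1CCCN(C(=O)CN2CN(c3ccccc3)C3(CCN(C(=O)c4ccc(C5CCCCC5)cc4)CC3)C2=O)C1` in an assay on HEK293 cells for displacement of a labelled ligand from NPC1-like intracellular cholesterol transporter 1 (Homo sapiens) (a lower number here means a stronger inhibitor, a higher number a weaker inhibitor), gives 3600 nM.
Compound 2 `CS(=O)(=O)NCCNC(=O)CN1CN(c2ccccc2)C2(CCN(C(=O)c3ccc(C4CCCCC4)cc3)CC2)C1=O` in this assay gives 2100 nM.
Compound 3 `NC(=O)C1CCCN(C(=O)CN2CN(c3ccccc3)C3(CCN(C(=O)c4ccc(C5CCCCC5)cc4)CC3)C2=O)C1` in this assay gives 3100 nM.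

The three compounds share a core and differ only in the group attached to the carbonyl carbon of the side chain. Compound 3 stands second highest of the three numbers; its nearest neighbour is compound 1, with a 1.2-fold lower number from compound 1 to compound 3 (0.06 log units; within the scatter), and its furthest is compound 2, with a 1.5-fold higher number from compound 2 to compound 3 (0.17 log units; within the scatter). The remaining pair shows a 1.7-fold lower number from compound 1 to compound 2 (0.23 log units; within the scatter). None of these exchanges at the carbonyl carbon moves the number beyond the scatter.

Compound 4 `CS(=O)(=O)N1CCN(C(=O)CN2CN(c3ccccc3)C3(CCN(C(=O)c4ccc(C5CCCCC5)cc4)CC3)C2=O)CC1` is not yet measured. It differs from compound 3 by 4-(methylsulfonyl)piperazin-1-yl in place of 3-carbamoylpiperidin-1-yl on a carbonyl carbon. All three measured steps bear on it, since each swaps the group on the same carbonyl carbon, and each stayed within the scatter; the sulfonyl-bearing compound 2 gave the lowest number of the three. A step from compound 3 to compound 4 of about a 1.2-fold lower number from compound 3 to compound 4 (0.08 log units; within the scatter) is therefore expected, with no change beyond the scatter. In this assay compound 4 is estimated at 2600 nM, with a range from 1200 nM to 5500 nM.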

Compound 4, half-maximal inhibitory concentration: 6300 nM
Compound 4: the middle estimate sits 2.4-fold (0.38 log units) below what was measured; the measured number lies above the stated range.
By their numbers in this assay, from the lowest: compounds 2, 3, 1 and 4 (each within the scatter of the next, the first and the last beyond it).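

In this assay the group on this carbonyl carbon can move the number beyond the scatter: there is a 2.0-fold higher number from compound 3 to compound 4 (0.31 log units; beyond the scatter) and a 3.0-fold higher number from compound 2 to compound 4 (0.48 log units; beyond the scatter) while a 1.8-fold higher number from compound 1 to compound 4 (0.24 log units; within the scatter) stays within it. A sulfonyl-bearing group therefore does not by itself keep the number low, as compound 2 with (2-(methanesulfonamido)ethyl)amino and compound 4 with 4-(methylsulfonyl)piperazin-1-yl differ beyond the scatter. No measurement at hand accounts for these steps.

Open, as far as these compounds go, is whether the rise from compound 3 to compound 4 follows from the loss of 3-carbamoylpiperidin-1-yl or from the methylsulfonyl on the piperazine ring. A plain piperazin-1-yl or a 4-acetylpiperazin-1-yl group on the same carbonyl carbon would bear on that question.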